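Swapping a Methylphenyl for Cyclopropyl at the Chain End

This account rests on a few compounds, and the source may have more. Where it says the series, first, only, none or still open, it means among the compounds named here.

Compound 1 `CCCCc1cnc(C(CCC)Cc2ccc(-c3ccccc3C(=O)O)cc2)[nH]1`: 1180 nM
Compound 2 `CCC(C)(C)Cc1c[nH]c(CCc2ccc(-c3ccccc3C(=O)O)cc2)n1`: 25 nM
Compound 3 `Cc1cccc(Cc2cnc(CCc3ccc(-c4ccccc4C(=O)O)cc3)[nH]2)c1`: 4310 nM

Of the compounds shown here, three on a shared core have been tested in an in vitro functional assay on cells for agonist activity at Bombesin receptor subtype-3 (Homo sapiens), read by luminescence and calcium flux; a lower number here means that less compound is needed, a higher number that more compound is needed for the effect. Compound 3 stands highest of the three numbers: its value lies beyond the scatter above that of compound 1, and well beyond the scatter above that of compound 2, the lowest of the set.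

Compound 4 `O=C(O)c1ccccc1-c1ccc(CCc2ncc(CC3CC3)[nH]2)cc1` has not yet been measured in this assay. It differs from compound 3 in one place: cyclopropyl in place of 3-methylphenyl on a saturated chain carbon bound to an aromatic carbon. Going by the values given here, no step between two measured compounds is available for this change, so what it may do has to be read from the three values alone. Among the compounds with values here, the one compound carrying a saturated group in this place, compound 2, gives 25 nM, and on that ground the number for compound 4 is expected to fall below that of compound 3, by a step beyond the scatter, estimated as a 7.2-fold lower number from compound 3 to compound 4 (0.86 log units; beyond the scatter). Compound 4 is therefore expected to give about 600 nM in this assay, with a likely range from 150 nM to 2500 nM.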

Compound 4, half-maximal effective concentration: 1000 nM
Compound 4: middle estimate off by 1.7-fold (0.22 log units), on the low side, and the stated range covers the measured number.
By their numbers in this assay, from the lowest: compound 2; then compounds 4 and 1 (each within the scatter of the next); then compound 3.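

In this assay, cyclopropyl in place of 3-methylphenyl on a saturated chain carbon bound to an aromatic carbon gives a 4.3-fold lower number from compound 3 to compound 4 (0.63 log units; beyond the scatter) (a modest step), so an aromatic ring at this place is not required for a lower number. The saturated ring alone does not bring the number down to the level of the saturated chain group, since compound 4 gives (1000 nM) and compound 2 gives (25 nM) on the same core. Nothing measured here accounts for either difference.

From the compounds shown here alone, it remains open how a cyclobutyl or cyclohexyl ring, or an amine, would read at this place. Going by these compounds, the unsubstituted phenyl group is also open, so the part played by the methyl on the aromatic ring of compound 3 cannot be separated from that of the ring itself.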